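This account rests on a few compounds, and the source may have more. Where it says the series, first, only, none or still open, it means among the compounds named here.

Working notes on the series. In a functional assay on PC-3 cells (Homo sapiens) for antiproliferative activity, read by MTT assay, with a stated time of 48 h (a higher number here means a weaker inhibitor, a lower number a stronger inhibitor), compound 1 `CC1(C)Cc2c(ccc(C(=O)/C=C/c3cn(-c4ccccc4)nc3-c3cccc([N+](=O)[O-])c3)c2OCc2ccccc2)O1` gives > 100000 nM, which is a limit of the assay and not a number. Compound 2 `CC1(C)Cc2c(ccc(C(=O)/C=C/c3ccccc3)c2OCc2ccccc2)O1` likewise reaches only a limit, > 100000 nM. Compound 3 `CC1(C)Cc2c(ccc(C(=O)/C=C/c3ccc(Br)cc3)c2OCc2ccccc2)O1` stands at > 50000 nM, again a limit in this assay. Going by the values given here, the one measured step, a step that the two limits leave unreadable from compound 2 to compound 3, stays unreadable because the limit of > 100000 nM in this assay, at which 2 of the 3 values shown sit, and the limit of > 50000 nM in this assay, at which 1 of the 3 values shown sits, bound it from one side only. Compound 4 `CC1(C)Cc2c(ccc(C(=O)/C=C/c3ccc(F)cc3)c2OCc2ccccc2)O1` differs from compound 3 by fluoro in place of bromo on an aromatic carbon. Among the compounds with values here, no measured step speaks to a change of this kind, and compound 3 itself is known only as a limit. Compound 4 is therefore expected to sit at a limit as well, estimated at 100000 nM with a range from 30000 nM to 300000 nM. The expected step, a step that the limit leaves unreadable from compound 3 to compound 4, is estimated as none beyond the scatter.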

Compound 4, half-maximal inhibitory concentration: 44200 nM
Estimate against measurement, compound 4: 2.3-fold (0.35 log units) above; the range from low to high includes it.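

In this assay, compound 4 gives the first actual number among the compounds shown, so the place para to a large group can now be read at all. Fluoro in place of hydrogen gives an at least 2.2-fold lower number from compound 2 to compound 4 (0.35 log units; beyond the scatter). Fluoro in place of bromo gives an at least 1.1-fold lower number from compound 3 to compound 4 (0.05 log units; that floor lies within the scatter), so no order between fluoro and bromo is settled.

On these data alone, the full size of both steps stays open, since each rests on a limit for the compared compound. Also open, as far as these compounds go, is how an amine or a carboxylic acid at this place would read.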